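Swapping the pyrrole for a thiophene

This account rests on a few compounds, and the source may have more. Where it says the series, first, only, none or still open, it means among the compounds named here.

Compound 2 `CCN(Cc1cc[nH]c1)C(=O)COc1ccc(C)cc1` sits at the high end of the two numbers available: in an assay on HEK293 cells for agonist activity at transient receptor potential cation channel subfamily M member 8 (Homo sapiens), read by fluorescence and calcium flux, with a stated time of 15 min (a lower number here means that less compound is needed, a higher number that more compound is needed for the effect), compound 2 gives 21800 nM, whereas compound 1 `CCN(Cc1ccoc1)C(=O)COc1ccc(C)cc1` gives 136 nM in this assay. Within the data shown here, the single measured step, a 160-fold higher number from compound 1 to compound 2 (2.20 log units; beyond the scatter), is the only one that bears on the change at hand. Compound 3 `CCN(Cc1ccsc1)C(=O)COc1ccc(C)cc1` differs from compound 2 by thiophen-3-yl in place of 1H-pyrrol-3-yl on a saturated chain carbon bound to an amide-type nitrogen. The group that leaves carries one hydrogen-bond donor and no hydrogen-bond acceptor; the group that enters carries no donor and one acceptor, which places compound 3 closer in this respect to compound 1 than to compound 2. Since the move from the furan of compound 1 to the pyrrole of compound 2 was accompanied by the large step of a 160-fold higher number from compound 1 to compound 2 (2.20 log units; beyond the scatter), the move away from the pyrrole is expected to run the other way, with a large fall in the number, though not necessarily all the way back. For compound 3 the expected step is an 87-fold lower number from compound 2 to compound 3 (1.94 log units; beyond the scatter). Compound 3 is therefore estimated at 250 nM, with a range from 50 nM to 2000 nM.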

Compound 3, half-maximal effective concentration: 88 nM
Beside the measured number, compound 3's estimate is 2.8-fold (0.45 log units) above it; low and high end bracket the measured number.
By their numbers in this assay, from the lowest: compounds 3 and 1 (each within the scatter of the next); then compound 2.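

At this place, on a saturated chain carbon bound to an amide-type nitrogen, the high number of compound 2 now stands apart from two different rings: in this assay, replacing 1H-pyrrol-3-yl with thiophen-3-yl gives a second large step (a 250-fold lower number from compound 2 to compound 3 (2.39 log units; beyond the scatter)). The furan and thiophene rings, by contrast, cannot be told apart here (a 1.5-fold lower number from compound 1 to compound 3 (0.19 log units; within the scatter)), so a change of ring does not by itself move the number far. Among these three compounds, the high number goes with the only group that carries a hydrogen-bond donor, 1H-pyrrol-3-yl, and no compound shown goes against this, though three compounds are a very small set and this link does not establish a cause.

Still open, as far as these compounds go, is whether the amide-type chain tolerates a larger or differently built group at this place, such as phenyl or pyridin-3-yl, and whether a 1-methylpyrrol-3-yl group, which keeps the pyrrole ring but replaces its nitrogen hydrogen with methyl, would behave like the pyrrole or like the furan and thiophene. No measurement given here explains why the pyrrole differs from the other two rings.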